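The compounds below may be only part of what the source reports. "The series", "measured", "known", "first", "only" and "open" are said of these compounds alone.

Of the compounds shown here, three have been tested so far in a functional assay on HMEC-1 cells (Homo sapiens) for antiproliferative activity, read by cell counting, with a stated time of 7 days; a lower number here means a stronger inhibitor, a higher number a weaker inhibitor. For the measured compounds named here, compound 1 `CCOC(=O)C(=O)N(Cc1cc(F)cc(F)c1)c1ccc2c(c1)OC(C)(CO)CN2C` gives 89000 nM, the only true number in the set. Compound 2 `CCOC(=O)CN(Cc1cc(F)cc(F)c1)c1ccc2c(c1)N(C)CC(C)(COc1ccc(C#N)cc1)O2` gives > 100000 nM, which is a limit of the assay and not a number. Compound 3 `CCOC(=O)CN(Cc1cccc(F)c1)c1ccc2c(c1)N(C)CC(C)(COc1ccc(C#N)cc1)O2` gives > 100000 nM, and this too is a limit. Compound 2 therefore has no exact position on the scale, and the data so far stop at the limit of > 100000 nM in this assay, at which 2 of the 3 values shown sit.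

The next molecule, compound 4 `CCOC(=O)CN(Cc1cc(F)cc(F)c1)c1ccc2c(c1)N(C)CC(C)(COc1ccc(C(=N)N)cc1)O2`, differs from compound 2 in one group on an aromatic carbon, para to a large group: a group of 3 heavy atoms (1 carbon, 2 nitrogen; no ring) in place of a group of 2 heavy atoms (1 carbon, 1 nitrogen; no ring), on an aromatic carbon. Cyano leaves, and a group with no common name enters. Going by the values given here, the one measured step is a step that the two limits leave unreadable from compound 2 to compound 3, and it concerns a different place on the molecule, so no measured step gives a size for this change.

Among the compounds with values here, only a modest move toward stronger inhibition is expected, and compound 1 at 89000 nM is the only readable value so far. The estimated change is an at least 1.6-fold lower number from compound 2 to compound 4 (0.22 log units; that floor lies within the scatter), and the result may again be only a limit. For compound 4 the expected value is 60000 nM, with an estimated range of 15000 nM to 200000 nM.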

Compound 4, half-maximal inhibitory concentration: 6700 nM
Compound 4: the middle estimate sits 9.0-fold (0.95 log units) above what was measured; the measured number lies below the stated range.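

In this assay, the group on the aromatic carbon para to a large group turns out to matter: with cyano leaving and a group of 3 heavy atoms (1 carbon, 2 nitrogen; no ring) entering, and nothing else changed, the result is an at least 14-fold lower number from compound 2 to compound 4 (1.17 log units; beyond the scatter). For the compounds shown here, the only earlier step cannot be read, so this is the first sign in the set that a single change in one place can bring a compound down from the limit to a true number. The size given is a floor and not an exact figure, because compound 2 carries only a limit, which is not a number: the limit of > 100000 nM in this assay, at which 2 of the 4 values shown sit.

What the compounds shown leave open is which difference in the entering group counts, whether its 2 hydrogen-bond donors or something else that separates it from cyano. They also leave open whether another group on the same aromatic carbon, such as an amine or a carboxylic acid, would give a step of similar size.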